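Pyrrole for Thiophene on the Shared Core: Compound 4 Expected

The source may hold more compounds than are shown below. What is called first, only, known or untested is meant among the compounds shown, and "the series" means these compounds.

Measured compounds:
compound 1 `Cn1nccc1-c1ncnc2c1ncn2C1O[C@H](CO)[C@@H](O)[C@H]1O`, "not active" (no number reported)
compound 2 `OC[C@H]1OC(n2cnc3c(-c4ccoc4)ncnc32)[C@H](O)[C@@H]1O`, 1650 nM
compound 3 `Cc1csc(-c2ncnc3c2ncn3C2O[C@H](CO)[C@@H](O)[C@H]2O)c1`, 2900 nM

In a functional assay on CCRF-CEM cells (Homo sapiens) for inhibition (on this read-out higher numbers stand for weaker inhibition and lower numbers for stronger inhibition), compound 3 gives 2900 nM, the highest of the two numbers reported; its nearest neighbour is compound 2, with 1650 nM, and the step of a 1.8-fold higher number from compound 2 to compound 3 (0.24 log units; within the scatter) lies within the scatter. Among the compounds with values here, compound 1 is reported only as "not active" (no number reported), with no number attached, so no step to it can be sized.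

Compound 4 `Cn1cccc1-c1ncnc2c1ncn2C1O[C@H](CO)[C@@H](O)[C@H]1O` differs from compound 3 by 1-methyl-1H-pyrrol-2-yl in place of 4-methylthiophen-2-yl on an aromatic carbon. Within the data shown here, only one measured step bears on this kind of swap of one five-membered aromatic ring for another on the shared core, a 1.8-fold higher number from compound 2 to compound 3 (0.24 log units; within the scatter), and it was within the scatter. Compound 1, which carries a different five-membered ring bearing a methyl on a ring nitrogen, gives "not active" (no number reported), which points toward the possibility of a weaker result but cannot be sized.

For compound 4 the expected step is therefore a 2.1-fold higher number from compound 3 to compound 4 (0.32 log units; beyond the scatter) in this assay, with a wide range. The estimate for compound 4 is 6000 nM, between 1500 nM and 30000 nM.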

Compound 4, half-maximal inhibitory concentration: 2000 nM
Estimate against measurement, compound 4: 3.0-fold (0.48 log units) above; low and high end bracket the measured number.
By their numbers in this assay, from the lowest: compounds 2, 4 and 3 (each within the scatter of the next).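

Swapping 4-methylthiophen-2-yl for 1-methyl-1H-pyrrol-2-yl gives a 1.5-fold lower number from compound 3 to compound 4 (0.16 log units; within the scatter) in this assay, and swapping furan-3-yl for the same group gives a 1.2-fold higher number from compound 2 to compound 4 (0.08 log units; within the scatter), so all three five-membered aromatic rings at this position, on the aromatic carbon next to the ring nitrogen, now lie within the scatter of one another. Compound 4 also carries a methyl on a ring nitrogen and still has a number, so that feature alone does not go with the result for compound 1, reported as "not active" (no number reported), although the step between these two compounds cannot be read. Nothing available gives a measured property or any other explanation for these results.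

Going by these compounds, what distinguishes the ring of compound 1 from that of compound 4 in this read-out remains open, since the result for compound 1 has no size. On these data alone, it is equally open whether a phenyl ring, an amine, a carboxylic acid or a longer chain on the same carbon of the shared core would stay within this narrow band or move clearly away from it.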